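Chain extension at the aryl ether of compound 2

The source may hold more compounds than are shown below. What is called first, only, known or untested is meant among the compounds shown, and "the series" means these compounds.

Compound 1 `Cn1ncc2c(NS(=O)(=O)c3cccc(Cl)c3Cl)ncnc21` and compound 2 `COc1nn(C)c2ncnc(NS(=O)(=O)c3cccc(Cl)c3Cl)c12` share one core and one sulfonamide arm and differ only at one aromatic carbon. In a functional assay on cells for antagonist activity at C-C chemokine receptor type 4 (Homo sapiens), read by GTPgammaS binding (a higher number here means a weaker inhibitor, a lower number a stronger inhibitor), compound 1 gives 1260 nM, and in this assay compound 2 gives 63.1 nM. The step of a 20-fold lower number from compound 1 to compound 2 (1.30 log units; beyond the scatter) is the only one measured so far, and it leaves compound 2 with the lower of the two numbers.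

Compound 3 `COCCOc1nn(C)c2ncnc(NS(=O)(=O)c3cccc(Cl)c3Cl)c12` carries the same core; the change from compound 2 is methoxymethyl in place of hydrogen on a saturated chain carbon bound to an oxygen on an aromatic ring. For the measured compounds named here, the one measured step concerns the aromatic carbon itself, not the chain on its oxygen, so it bears on compound 3 only indirectly: it shows that an oxygen substituent at that carbon is accepted with a large gain, but says nothing about lengthening that substituent. Going by the values given here, no step of this kind has been measured. The expectation for compound 3 is therefore a small step in this assay, if any, and no direction can be claimed beyond the scatter; the expected step is a 1.3-fold higher number from compound 2 to compound 3 (0.10 log units; within the scatter). Compound 3 is estimated at 80 nM, with a range from 25 nM to 250 nM.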

Compound 3, half-maximal inhibitory concentration: 794 nM
For compound 3 the middle estimate is 9.9-fold (1.00 log units) below the measured one; the whole stated range lies below it.
By their numbers in this assay, from the lowest: compound 2; then compounds 3 and 1 (each within the scatter of the next).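

In this assay, going from methoxy to 2-methoxyethoxy on the aromatic carbon gives a 13-fold higher number from compound 2 to compound 3 (1.10 log units; beyond the scatter), so the chain on this oxygen is not a free exit point: this extension at the saturated chain carbon bound to the oxygen is not accepted as the methoxy is. Measured against the hydrogen of compound 1, the 2-methoxyethoxy group gives a 1.6-fold lower number from compound 1 to compound 3 (0.20 log units; within the scatter), so the gain seen with methoxy (a 20-fold lower number from compound 1 to compound 2 (1.30 log units; beyond the scatter)) does not follow from having just any oxygen substituent on this carbon and does not survive in compound 3. Nothing at hand bears on why the added methoxymethyl has this effect.

The compounds shown leave open whether the loss follows chain length alone or the second ether oxygen of the chain, a question that ethoxy and a plain propoxy chain would address. They also leave open whether a chain ending in an amine, such as 2-aminoethoxy, or in a carboxylic acid would track compound 2 or compound 3 in this assay.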